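The compounds below may be only part of what the source reports. "The series", "measured", "known", "first", "only" and "open" are said of these compounds alone.

Working notes on the cinnamoyl series sharing the core of compound 1 `O=C(/C=C/c1ccc2c(c1)B(O)OC2)c1ccc(F)cc1`. In a functional assay on MDA-MB-231 cells (Homo sapiens) for cytotoxicity, read by MTT assay, with a stated time of 48 h (on this read-out lower numbers stand for stronger inhibition and higher numbers for weaker inhibition), compound 1 gives 1600 nM. Compound 2 `O=C(/C=C/c1ccc2c(c1)B(O)OC2)c1ccc(I)cc1` gives 14900 nM, the change being a 9.3-fold higher number from compound 1 to compound 2 (0.97 log units; beyond the scatter). Compound 3 `O=C(/C=C/c1ccc2c(c1)B(O)OC2)c1ccc(O)cc1` gives 25600 nM, the highest of the three numbers; against compound 1 the step is a 16-fold higher number from compound 1 to compound 3 (1.20 log units; beyond the scatter), while against compound 2 it is only a 1.7-fold higher number from compound 2 to compound 3 (0.24 log units; within the scatter).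

Compound 4 `O=C(/C=C/c1ccc2c(c1)B(O)OC2)c1cccc(F)c1` is not yet measured. The change from compound 3 is 3-fluorophenyl in place of 4-hydroxyphenyl on a carbonyl carbon. Within the data shown here, of the measured steps, the one from compound 1 to compound 3 bears most directly on it, since it swaps fluoro for hydroxy on the same aromatic ring and was large; reversing that swap is the main part of the change to compound 4. Among the measured compounds shown here, the data hold no step in which a fluoro is moved from one aromatic carbon to another, so the effect of the fluoro standing in the 3-position of the phenyl rather than the position used in compound 1 is unknown. A lower number than compound 3 is therefore expected, probably of modest to large size, with wide uncertainty: the expected step is a 7.3-fold lower number from compound 3 to compound 4 (0.86 log units; beyond the scatter). For compound 4 in this assay the estimate is 3500 nM, with a range from 900 nM to 14000 nM.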

Compound 4, half-maximal inhibitory concentration: 3000 nM
Compound 4: the middle estimate sits 1.2-fold (0.07 log units) above what was measured; low and high end bracket the measured number.
By their numbers in this assay, from the lowest: compounds 1 and 4 (each within the scatter of the next); then compounds 2 and 3 (each within the scatter of the next).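

Moving the fluoro, with 3-fluorophenyl in place of 4-fluorophenyl on the carbonyl carbon, gives a 1.9-fold higher number from compound 1 to compound 4 (0.27 log units; within the scatter), so this assay does not separate these two fluorophenyl groups, a comparison the earlier compounds could not offer. The other two steps set 3-fluorophenyl apart from the remaining groups: against 4-hydroxyphenyl there is an 8.5-fold lower number from compound 3 to compound 4 (0.93 log units; beyond the scatter), and against 4-iodophenyl there is a 5.0-fold lower number from compound 2 to compound 4 (0.70 log units; beyond the scatter), so compound 1 and compound 4 form one group and compound 2 and compound 3 another. No measurement at hand accounts for these differences.

On these data alone, it remains open whether an unsubstituted phenyl, or a phenyl carrying a chloro, a methoxy, an amine or a carboxylic acid, would fall with compound 1 and compound 4 or with compound 2 and compound 3. Iodo and hydroxy appear only as 4-iodophenyl and 4-hydroxyphenyl, so whether the match between 3-fluorophenyl and 4-fluorophenyl extends to any group other than fluoro is also open.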